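The source may hold more compounds than are shown below. What is called first, only, known or untested is meant among the compounds shown, and "the series" means these compounds.

Three compounds share one core and differ only at the side chain attached through a saturated chain carbon to the ring. Compound 1 `CCCCNC(=O)NCc1ccc(CCCC)n(Cc2ccc(-c3ccccc3-c3nn[nH]n3)cc2)c1=O` carries a (butylcarbamoyl)amino group there and gives 10 nM in a functional assay (aorta) for antagonist activity, with Oryctolagus cuniculus as the target; on this read-out lower numbers stand for stronger inhibition and higher numbers for weaker inhibition. Compound 2 `CCCCc1ccc(CNC(=O)N(C)C)c(=O)n1Cc1ccc(-c2ccccc2-c2nn[nH]n2)cc1` gives 2 nM, and compound 3 `CCCCc1ccc(CN(Cc2ccccc2)S(C)(=O)=O)c(=O)n1Cc1ccc(-c2ccccc2-c2nn[nH]n2)cc1` gives 2 nM. The step of a 5.0-fold lower number from compound 1 to compound 2 (0.70 log units; beyond the scatter) and the step of a 5.0-fold lower number from compound 1 to compound 3 (0.70 log units; beyond the scatter) both show that the butylamino variant is weaker, while the step of no change at the digits printed from compound 2 to compound 3 (within the scatter) shows no difference between a dimethylcarbamoyl and a benzyl(methylsulfonyl) group. Compound 3 thus stands level with compound 2, and the two are together the lowest numbers of the set.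

Compound 4 `CCCCc1ccc(CN(C)S(C)(=O)=O)c(=O)n1Cc1ccc(-c2ccccc2-c2nn[nH]n2)cc1` is compound 3 with hydrogen in place of phenyl on a saturated chain carbon bound to a sulfonamide nitrogen, so the group becomes methyl(methylsulfonyl)amino. Within the data shown here, no measured step removes a phenyl from this nitrogen; the nearest evidence is the step of no change at the digits printed from compound 2 to compound 3 (within the scatter), where two rather different groups gave the same number, and the step of a 5.0-fold lower number from compound 1 to compound 2 (0.70 log units; beyond the scatter), where trimming the chain helped. Variation at this position therefore looks tolerated, and only a small step is expected, a 1.5-fold higher number from compound 3 to compound 4 (0.18 log units; within the scatter). The expected value for compound 4 in this assay is 3 nM, within 1 nM to 10 nM.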

Compound 4, half-maximal inhibitory concentration: 0.2 nM
For compound 4 the middle estimate is 15-fold (1.18 log units) above the measured one; the whole stated range lies above it.
By their numbers in this assay, from the lowest: compound 4; then compounds 2 and 3 (each within the scatter of the next); then compound 1.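

Replacing the phenyl with hydrogen, which turns benzyl into methyl on the sulfonamide nitrogen, gives a 10-fold lower number from compound 3 to compound 4 (1.00 log units; beyond the scatter) in this assay. The earlier compounds shown here showed only that a dimethylcarbamoyl and a benzyl(methylsulfonyl) side chain could sit level, whereas this result shows that the substituent on the sulfonamide nitrogen can shift the number clearly. Methyl(methylsulfonyl)amino also stands apart from the other two side chains, with a 10-fold lower number from compound 2 to compound 4 (1.00 log units; beyond the scatter) and a 50-fold lower number from compound 1 to compound 4 (1.70 log units; beyond the scatter) placing compound 4 lowest of the four, but no measurement here explains what the phenyl does at this position.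

The compounds shown leave open how the number responds to an ethyl or propyl chain on the sulfonamide nitrogen, which lie in size between methyl and benzyl, or to a bare hydrogen on that nitrogen. They also leave open how much the methylsulfonyl part itself contributes, a question that an ethylsulfonyl, phenylsulfonyl or acetyl group in its place would help to answer.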